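The compounds below may be only part of what the source reports. "The series", "measured", "known", "first", "only" and "open" are said of these compounds alone.

Compounds measured so far:
compound 1 `c1ccc(CN2CCN(CCCc3c[nH]c4ccc(-n5cnnc5)cc34)CC2)nc1`, 0.4 nM in an assay on CHO cells for displacement of a labelled ligand from 5-hydroxytryptamine receptor 1D (Homo sapiens); a higher number here means a weaker inhibitor, a lower number a stronger inhibitor
compound 2 `c1cc2[nH]cc(CCCN3CCNCC3)c2cc1-n1cnnc1`, 31 nM

Compound 1 holds the lowest of the two numbers; the nearest is compound 2, with a 78-fold higher number from compound 1 to compound 2 (1.89 log units; beyond the scatter). Compound 3 `c1ccc(N2CCN(CCCc3c[nH]c4ccc(-n5cnnc5)cc34)CC2)cc1` differs from compound 1 by phenyl in place of (pyridin-2-yl)methyl on an amine nitrogen in a ring. Within the data shown here, only the step from compound 1 to compound 2 bears on this change, and it shows that losing the (pyridin-2-yl)methyl group entirely costs much potency. Compound 3 keeps an aromatic ring on that nitrogen, so a smaller loss is expected, a 7.5-fold higher number from compound 1 to compound 3 (0.88 log units; beyond the scatter). Compound 3 is therefore estimated at 3 nM, within 0.8 nM to 12 nM.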

Compound 3, half-maximal inhibitory concentration: 1.4 nM
Compound 3: middle estimate off by 2.1-fold (0.33 log units), on the high side; the range from low to high includes it.
By their numbers in this assay, from the lowest: compound 1; then compound 3; then compound 2.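

Phenyl on this amine nitrogen gives a 22-fold lower number from compound 2 to compound 3 (1.35 log units; beyond the scatter), so a ring attached directly there, with no ring nitrogen, already provides a large gain over hydrogen. Replacing (pyridin-2-yl)methyl with phenyl gives a 3.5-fold higher number from compound 1 to compound 3 (0.54 log units; beyond the scatter), a modest cost compared with removing the substituent altogether. No evidence is available to explain either step.

This change removes the ring nitrogen and the methyl link together, so the compounds shown cannot separate their contributions. Benzyl and pyridin-2-yl on this nitrogen, each differing from compound 3 in only one of those features, remain open.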